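The compounds below may be only part of what the source reports. "The series", "measured", "known", "first", "only" and "open" are said of these compounds alone.

Among the measured compounds shown here, compound 2, with structure `CCNC(=O)n1ccc(Cn2c(C(=O)CC)c(-c3ccccc3)c3cc(Cl)ccc3c2=O)n1`, is the more lipophilic of the two compounds measured so far in a physicochemical assay for lipophilicity, at pH 7.4; a lower number here means a more polar compound, a higher number a more lipophilic compound: compound 2 gives 4.51. Its nearest neighbour is compound 1, with structure `CCC(=O)c1c(-c2ccccc2)c2cc(Cl)ccc2c(=O)n1Cc1cc(C(N)=O)n(CC)n1`, which in this assay gives 4.08. For the measured compounds named here, the single change between them, where a 1-(ethylcarbamoyl)-1H-pyrazol-3-yl group takes the place of a 5-carbamoyl-1-ethyl-1H-pyrazol-3-yl group on a saturated chain carbon bound to an aromatic nitrogen, moved the read-out by a number 0.43 log units higher from compound 1 to compound 2 (beyond the scatter).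

Compound 3, with structure `CCC(=O)c1c(-c2ccccc2)c2cc(Cl)ccc2c(=O)n1Cc1cc(C(=O)NC)[nH]n1`, has not yet been measured. It differs from compound 2 by 5-(methylcarbamoyl)-1H-pyrazol-3-yl in place of 1-(ethylcarbamoyl)-1H-pyrazol-3-yl on a saturated chain carbon bound to an aromatic nitrogen. Going by the values given here, the only step that bears on this change is the one from compound 1 to compound 2, in which the same shared core carried the ethylcarbamoyl-substituted pyrazole on one side and a carbamoyl-substituted pyrazole on the other, and it was of modest size. Because compound 1 gave 4.08, the return to a carbamoyl-substituted pyrazole in compound 3 is expected to bring the read-out back down, by a step of about a number 0.61 log units lower from compound 2 to compound 3 (beyond the scatter) in this assay. Compound 3 is therefore estimated at 3.9, within a range from 3.5 to 4.3.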

Compound 3, distribution coefficient: 3.5
The estimate for compound 3 lay 0.40 log units above the measured number; measured number inside the range.
By their numbers in this assay, from the lowest: compound 3; then compound 1; then compound 2.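

At the saturated chain carbon bound to an aromatic nitrogen, the change to 5-(methylcarbamoyl)-1H-pyrazol-3-yl gives in this assay a number 1.01 log units lower from compound 2 to compound 3 (beyond the scatter), a large step, and a number 0.58 log units lower from compound 1 to compound 3 (beyond the scatter), a modest one, so compound 3 stands lowest of the three. The position therefore tolerates a wider spread among substituted pyrazoles than the single modest step between compound 1 and compound 2 had shown, and the order of the three is now fixed with every gap beyond the scatter. The step from compound 2 changes the ethyl to a methyl and also the placing of the amide on the pyrazole, with hydrogen-bond donors and acceptors counted differently, and nothing measured on these compounds assigns the size of the step to any one of these differences.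

On these data alone, a compound carrying 5-(ethylcarbamoyl)-1H-pyrazol-3-yl at this place would separate the chain length from the rest of the change, and that comparison remains open. Also open, as far as these compounds go, is how this read-out would respond to a carboxylic acid or an amine on the pyrazole in place of the amide.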